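Amine substituent replacement: from compound 2 to compound 3

The source may report more compounds than this note shows. Statements on the series, on what has been measured and on what is new or still open speak of the compounds shown alone.

Measured so far:
compound 1 `CN(Cc1cccs1)C1CCN(CCCc2c[nH]c3ccc(-n4cnnc4)cc23)CC1` — 3.5 nM
compound 2 `c1ccc2c(c1)CCC2NC1CCN(CCCc2c[nH]c3ccc(-n4cnnc4)cc23)CC1` — 25 nM

In an assay on CHO cells for agonist activity at 5-hydroxytryptamine receptor 1D (Homo sapiens), read by GTPgammaS binding (a higher number here means that more compound is needed for the effect, a lower number that less compound is needed), compound 1 gives 3.5 nM and compound 2 gives 25 nM. Among the compounds with values here, compound 2 stands highest of the two numbers, the only neighbour being compound 1, reached by the step of a 7.1-fold higher number from compound 1 to compound 2 (0.85 log units; beyond the scatter), which is beyond the scatter and modest in size.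

Compound 3 `NC(=O)OC[C@H](NC1CCN(CCCc2c[nH]c3ccc(-n4cnnc4)cc23)CC1)c1ccccc1` is not yet measured. It differs from compound 2 by 2-(carbamoyloxy)-1-phenylethyl in place of 2,3-dihydro-1H-inden-1-yl on an amine nitrogen. Within the data shown here, the only measured step that bears on this change is a 7.1-fold higher number from compound 1 to compound 2 (0.85 log units; beyond the scatter), which also altered the group on the amine nitrogen and moved the number up modestly. Compound 3 keeps a secondary amine bearing an aromatic-ring-containing group, as compound 2 does, so no further step beyond the scatter is expected, and a return toward compound 1 is possible but not supported by any measured step. Compound 3 is therefore expected to give 18 nM (range 5 nM to 70 nM), which means an expected step of a 1.4-fold lower number from compound 2 to compound 3 (0.14 log units; within the scatter).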

Compound 3, half-maximal effective concentration: 9.3 nM
Compound 3: middle estimate off by 1.9-fold (0.29 log units), on the high side; low and high end bracket the measured number.
By their numbers in this assay, from the lowest: compound 1; then compound 3; then compound 2.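

In this assay, the step of a 2.7-fold lower number from compound 2 to compound 3 (0.43 log units; beyond the scatter) shows that the group on this amine nitrogen tolerates more than a compact hydrocarbon: the five-membered non-aromatic ring of 2,3-dihydro-1H-inden-1-yl is gone, and 2-(carbamoyloxy)-1-phenylethyl, with its hydrogen-bond donor, two hydrogen-bond acceptors and defined stereocentre, gives a lower number. Together with the step of a 7.1-fold higher number from compound 1 to compound 2 (0.85 log units; beyond the scatter), which raised the number, this shows that changes in the amine substituent can move the number in either direction, whereas the earlier pair showed only a rise. No measurement available here accounts for the lower number of compound 3.

The single step changes the ring, the carbamoyloxy group and the stereocentre together, so the compounds shown do not assign the shift to any one of these features. Still open, going by these compounds, is how the number would respond to a 2-hydroxy-1-phenylethyl group or a 2-amino-1-phenylethyl group on the same nitrogen, or to the opposite configuration at the stereocentre of 2-(carbamoyloxy)-1-phenylethyl.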